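The compounds below may be only part of what the source reports. "The series", "measured", "known", "first", "only" and "open" are said of these compounds alone.

In an ADME assay on a cell-free system (plasma, Mus musculus) for metabolic stability, tested at 1 uM (on this read-out higher numbers stand for a longer-lived compound and lower numbers for a shorter-lived compound), compound 1 (`C=CC(=O)N[C@@H]1CCN(S(=O)(=O)c2ccc(NC(=O)OCc3ccccc3)cc2)C1`) gives > 6 h, which is a limit of the assay and not a number. Compound 2 (`C=CC(=O)NC1CCN(S(=O)(=O)c2ccc(C(=O)N[C@@H]3C[C@H]3c3ccccc3)cc2)CC1`) gives > 6 h, likewise a limit and not a number. Both compounds therefore stand at the same limit, with no number for either: the limit of > 6 h in this assay, at which 2 of the 2 values shown sit. Compound 3 (`C=CC(=O)NC1CCN(S(=O)(=O)c2ccc(C(=O)NC3CCCc4ccccc43)cc2)CC1`) carries 1,2,3,4-tetrahydronaphthalen-1-yl in place of 2-phenylcyclopropyl on an amide-type nitrogen. Among the measured compounds shown here, no measured step covers this change. The expected result in this assay is a step that the limit leaves unreadable from compound 2 to compound 3, in no clear direction and not beyond the scatter. Compound 3 is estimated at 8 h, with an expected range of 3 h to 20 h.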

Compound 3, half-life: > 6 h
Compound 3: a limit, no number; the forecaster's own chance of this, stated with the estimate: 75%; the middle value is on the limit's open side.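

No step from compound 2 to compound 3 can be read, because both values are limits and not numbers: the limit of > 6 h in this assay, at which 3 of the 3 values shown sit.

The compounds shown leave open how far compound 1, compound 2 and compound 3 differ in this assay, and whether 1,2,3,4-tetrahydronaphthalen-1-yl in place of 2-phenylcyclopropyl changes the half-life.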